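Swapping the ether oxygen for sulfur on a fused diamine core

The source may hold more compounds than are shown below. What is called first, only, known or untested is meant among the compounds shown, and "the series" means these compounds.

Compound 1, `Nc1cc(N)c2nc(-c3ccccc3)c(Oc3ccc(Cl)c(Cl)c3)nc2c1`: 17000 nM
Compound 2, `CCOC(=O)[C@H](CCC(=O)O)NC(=O)c1ccc(CNc2nc3cc(N)cc(N)c3nc2-c2ccccc2)cc1`: < 100000 nM
Compound 3, `CCOC(=O)[C@H](CCC(=O)O)NC(=O)c1ccc(Sc2nc3cc(N)cc(N)c3nc2-c2ccccc2)cc1`: 16200 nM

Of the compounds shown here, three built on the same fused diamine core have been tested in a functional assay on SF-268 cells (Homo sapiens) for inhibition, read by sulforhodamine B assay, with a stated time of 48 h; a lower number here means a stronger inhibitor of growth, a higher number a weaker inhibitor of growth. Compound 1 carries a 3,4-dichlorophenoxy group and gives 17000 nM. Compound 3, which carries a larger side chain joined to the core through sulfur, gives 16200 nM. The numbers for compound 1 and compound 3 lie so close together that the scatter of this assay does not separate them. Compound 2, whose side chain is joined to the core through nitrogen, is reported only as a limit, < 100000 nM, and not as a number (the limit of < 100000 nM in this assay, at which 1 of the 3 values shown sits). On the numbers shown, compound 1 thus sits together with compound 3, with compound 2 giving only a limit.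

The next compound, compound 4, `Nc1cc(N)c2nc(-c3ccccc3)c(Sc3ccc(Cl)c(Cl)c3)nc2c1`, differs from compound 1 in one place: (3,4-dichlorophenyl)sulfanyl in place of 3,4-dichlorophenoxy on an aromatic carbon. For the measured compounds named here, no measured pair shows this exact exchange, so its size cannot be read from a completed step. Given that compound 3, also linked through sulfur, gives 16200 nM close to compound 1, the step is expected to stay within the scatter, in no particular direction. For compound 4, then, the estimated value in this assay is 15000 nM, with a range from 5000 nM to 50000 nM, which corresponds to an expected step of a 1.1-fold lower number from compound 1 to compound 4 (0.05 log units; within the scatter).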

Compound 4, concentration for 50% growth inhibition: 13800 nM
For compound 4 the middle estimate is 1.1-fold (0.04 log units) above the measured one; low and high end bracket the measured number.
By their numbers in this assay, from the lowest: compounds 4, 3 and 1 (each within the scatter of the next).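

Exchanging 3,4-dichlorophenoxy for (3,4-dichlorophenyl)sulfanyl on this aromatic carbon, next to the ring nitrogen and ortho to a phenyl group, gives in this assay a step of a 1.2-fold lower number from compound 1 to compound 4 (0.09 log units; within the scatter). For the compounds shown here, this is the first exchange in the set that changes only one place, so the linking atom can now be judged on its own, whereas the earlier compounds differed in the whole side chain as well as in the link. With the dichlorophenyl ring kept, oxygen and sulfur are not told apart at this position in this assay, and nothing measured here bears on why the two read alike.

The compounds shown leave open whether a link of another kind, such as a sulfone, a carbonyl or a methylene group, would also leave the number within the scatter of compound 1. They also leave open whether the ring attached through the link tolerates change, for instance a trifluoromethyl group or a carboxylic acid in place of the two chlorines, and whether any such change would move growth inhibition beyond the scatter.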